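Varying the Terminal Ring at the End of the Chain

A few compounds are considered here, and "the series" means these few. Any claim that something is new, unique, unknown or untested is made for them only; others in the source may bear on it.

Compound 1, `COc1cc2c(Nc3ccc(C#N)cc3)ncnc2cc1OCCCN1CCCC1`, gives 8080 nM in a functional assay on SH-SY5Y cells (Homo sapiens) for antiproliferative activity, read by MTT assay, with a stated time of 72 h; a lower number here means a stronger inhibitor, a higher number a weaker inhibitor. Compound 2, `COc1cc2c(Nc3ccc(C#N)cc3)ncnc2cc1OCCCN1CCCCC1`, gives 18800 nM in this assay. Compound 3, `COc1cc2c(Nc3ccc(C#N)cc3)ncnc2cc1OCCCN1CCC(c2ccccc2)CC1`, gives 7770 nM in this assay.

All three compounds share one core and differ only in the ring that ends the three-carbon chain. For the measured compounds named here, compound 3 has the lowest of the three numbers, but the step of a 1.0-fold lower number from compound 1 to compound 3 (0.02 log units; within the scatter) lies within the scatter, so compound 3 and compound 1 cannot be separated; only the step of a 2.4-fold lower number from compound 2 to compound 3 (0.38 log units; beyond the scatter) is beyond the scatter, as is a 2.3-fold higher number from compound 1 to compound 2 (0.37 log units; beyond the scatter).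

Compound 4, `COc1cc2c(Nc3ccc(C#N)cc3)ncnc2cc1OCCCN1CCN(c2ccncc2)CC1`, is not yet measured. It differs from compound 3 by 4-(pyridin-4-yl)piperazin-1-yl in place of 4-phenylpiperidin-1-yl on a saturated chain carbon, three bonds along the chain from an oxygen on an aromatic ring. The measured steps show that exchanging the ring at this place has shifted the number only modestly in either direction. A change of similar size, or none beyond the scatter, is therefore expected for a 1.3-fold higher number from compound 3 to compound 4 (0.11 log units; within the scatter). Compound 4 is estimated to give 10000 nM in this assay, within a range from 3500 nM to 30000 nM.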

Compound 4, half-maximal inhibitory concentration: 31600 nM
For compound 4 the middle estimate is 3.2-fold (0.50 log units) below the measured one, and the stated range ends below it.
By their numbers in this assay, from the lowest: compounds 3 and 1 (each within the scatter of the next); then compounds 2 and 4 (each within the scatter of the next).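

For the compounds shown here, exchanging the ring at this place can shift the number by more than the earlier compounds showed: the replacement of 4-phenylpiperidin-1-yl by 4-(pyridin-4-yl)piperazin-1-yl gives the largest step so far (a 4.1-fold higher number from compound 3 to compound 4 (0.61 log units; beyond the scatter)), although both groups have 12 heavy atoms and two six-membered rings. A second ring at the end of the chain therefore does not settle the number in this assay by itself, and compound 4 also stands apart from the pyrrolidine compound (a 3.9-fold higher number from compound 1 to compound 4 (0.59 log units; beyond the scatter)). It cannot be separated from the piperidine compound, however (a 1.7-fold higher number from compound 2 to compound 4 (0.23 log units; within the scatter)). No measurement here explains the shift.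

The compounds shown change the saturated ring and the aromatic ring together, so the step cannot be assigned to either one. A 4-phenylpiperazin-1-yl group, which has the piperazine ring with a carbon-only aromatic ring, would separate these two changes.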